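Removing Two Methoxy Groups from an Ester Side Chain

The compounds below may be only part of what the source reports. "The series", "measured", "known", "first", "only" and "open" are said of these compounds alone.

Measured compounds:
compound 1, `C/C=C1/[C@H](O[C@@H]2O[C@H](COC(C)=O)[C@@H](OC(C)=O)[C@H](OC(C)=O)[C@H]2OC(C)=O)OC=C(C(=O)O)[C@H]1CC(=O)OC`: > 20000 nM
compound 2, `C/C=C1/[C@H](O[C@@H]2O[C@H](CO)[C@@H](O)[C@H](O)[C@H]2O)OC=C(C(=O)OC)[C@H]1CC(=O)OCCc1ccc(OC)c(OC)c1`: > 15000 nM
compound 3, `C=C(C)CCOC(=O)C[C@@H]1C(C(=O)OC)=CO[C@@H](O[C@@H]2O[C@H](COC(C)=O)[C@@H](OC(C)=O)[C@H](OC(C)=O)[C@H]2OC(C)=O)/C1=C/C`: > 15000 nM

Of the compounds shown here, three have been tested in a functional assay on SK-BR-3 cells (Homo sapiens) for antiproliferative activity, read by MTT assay, with a stated time of 72 h; on this read-out lower numbers stand for stronger inhibition and higher numbers for weaker inhibition. Compound 1 gives > 20000 nM, which is a limit of the assay and not a number. Compound 2 gives > 15000 nM, likewise only a limit. Compound 3 gives > 15000 nM, again a limit. Compound 2 therefore stands at the limit of > 15000 nM in this assay, at which 2 of the 3 values shown sit. Compound 1 stands at the limit of > 20000 nM in this assay, at which 1 of the 3 values shown sits. Among the compounds with values here, since none of the three values is a number, no step between them can be sized, and there is no measured step in this assay against which to gauge a new change.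

Compound 4, `C/C=C1/[C@H](O[C@@H]2O[C@H](CO)[C@@H](O)[C@H](O)[C@H]2O)OC=C(C(=O)OC)[C@H]1CC(=O)OCCc1ccccc1`, has not yet been measured. It differs from compound 2 in one place: phenyl in place of 3,4-dimethoxyphenyl on a saturated chain carbon, two bonds along the chain from an oxygen next to a carbonyl group. Whether the phenyl in place of the 3,4-dimethoxyphenyl shifts the result cannot be read from the three compounds, all of which sit at a limit. The expected step that the limit leaves unreadable from compound 2 to compound 4 is therefore none beyond the scatter. Compound 4 is expected to give about 20000 nM, in a range from 8000 nM to 50000 nM, and most likely the assay will again report only a limit for compound 4.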

Compound 4, half-maximal inhibitory concentration: 11000 nM
For compound 4 the middle estimate is 1.8-fold (0.26 log units) above the measured one, within the range that was stated.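

In this assay, within the data shown here, compound 4 gives 11000 nM as the first value in this set that is a number and not a limit, so the phenethyl group at this place on the ester side chain gives a read-out that the assay can report. Compound 2 remains a limit of the assay and not a number: the limit of > 15000 nM in this assay, at which 2 of the 4 values shown sit. The change can therefore be sized from one side only, as an at least 1.3-fold lower number from compound 2 to compound 4 (0.13 log units; that floor lies within the scatter) and no more, which shows that the two methoxy groups are not needed for a measurable value here but does not show that losing them brings a gain beyond the scatter.

On these data alone, the true distance between the 3,4-dimethoxyphenyl and phenyl compounds stays open while one of the pair sits at a limit, and so does the question of whether either methoxy group matters alone. Nor do the compounds shown tell whether a hydroxyl or an amine on the phenyl ring, or a chain longer than phenethyl, would move the value further in this assay at this place.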